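This account rests on a few compounds, and the source may have more. Where it says the series, first, only, none or still open, it means among the compounds named here.

In an in vivo ADME assay on the whole organism for pharmacokinetics, with Rattus norvegicus as the target, at a dose of 10 mg/kg by the oral route (a lower number here means less compound in the circulation, a higher number more compound in the circulation at the dose given), two compounds have been measured so far:
compound 1 `CC1(COc2c(N3CCN(S(=O)(=O)Cc4cccc(N)c4)CC3)cnn(-c3cccc(Cl)c3)c2=O)CC1` gives 2570 nM;
compound 2 `COc1cc(CS(=O)(=O)N2CCN(c3cnn(-c4cccc(Cl)c4)c(=O)c3OCC3(C)CC3)CC2)ccc1N` gives 5750 nM.

For the measured compounds named here, compound 2 stands highest of these two numbers, and the only measured step, a 2.2-fold higher number from compound 1 to compound 2 (0.35 log units; beyond the scatter), is what separates it from compound 1. Compound 3 `CC1(COc2c(N3CCN(S(=O)(=O)Cc4cccnc4N)CC3)cnn(-c3cccc(Cl)c3)c2=O)CC1` is the next step onward from compound 2. The change is 2-aminopyridin-3-yl in place of 4-amino-3-methoxyphenyl on a saturated chain carbon bound to a sulfonyl sulfur. Going by the values given here, the one measured step, a 2.2-fold higher number from compound 1 to compound 2 (0.35 log units; beyond the scatter), also swapped one amino-bearing aromatic ring for another at the same place and gave a modest rise. Among the compounds with values here, the present change swaps the ring again at that place, but it removes the 4-amino-3-methoxyphenyl that came with that rise and brings in a 2-aminopyridin-3-yl, which no measured compound carries. Within the data shown here, no measured step speaks to it directly, so the expected step of a 1.6-fold lower number from compound 2 to compound 3 (0.20 log units; within the scatter) is a small one toward a lower number, with wide uncertainty. Compound 3 is estimated at 3600 nM, within a range of 1300 nM to 10000 nM.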

Compound 3, maximal plasma concentration: 3120 nM
Estimate against measurement, compound 3: 1.2-fold (0.06 log units) above, and the stated range covers the measured number.
By their numbers in this assay, from the lowest: compounds 1, 3 and 2 (each within the scatter of the next, the first and the last beyond it).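

On a saturated chain carbon bound to a sulfonyl sulfur, an aromatic ring with a hetero atom can take the place of a carbon-only ring without a change that this assay can resolve. Replacing the 4-amino-3-methoxyphenyl gives a 1.8-fold lower number from compound 2 to compound 3 (0.27 log units; within the scatter), and replacing the 3-aminophenyl gives a 1.2-fold higher number from compound 1 to compound 3 (0.08 log units; within the scatter), so compound 3 cannot be separated from either compound, although those two differ from each other beyond the scatter. Nothing available accounts for these numbers.

Every compound shown carries an amino group on this ring, so what a hydroxyl group or a plain phenyl ring would do at this place remains open. Also open, as far as these compounds go, is whether a methoxy group added to the 2-aminopyridin-3-yl ring would bring the number closer to that of compound 2.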